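The source may hold more compounds than are shown below. What is called first, only, known or untested is meant among the compounds shown, and "the series" means these compounds.

Working notes on the series. Compound 3 `O=c1c(C(=S)Nc2ccccc2)coc2cc(Cl)c(Cl)cc12` is the reference for the first core; in a functional assay on A549 cells (Homo sapiens) for inhibition, read by sulforhodamine B assay, with a stated time of 48 h (a higher number here means a weaker inhibitor, a lower number a stronger inhibitor), compound 3 gives 71200 nM. Compound 1 `O=c1c(C(=S)Nc2ccccc2)coc2cc(Cl)ccc12` keeps that core and differs from compound 3 only by hydrogen in place of chloro on an aromatic carbon. In this assay compound 1 gives 63600 nM, and the step of a 1.1-fold lower number from compound 3 to compound 1 (0.05 log units; within the scatter) is therefore too small to separate the two compounds.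

Compound 2 `O=c1c(C2N=C(c3ccccc3)SS2)coc2cc(Cl)c(Cl)cc12` has the second core; the difference between the two cores is not broken down here. In this assay compound 2 gives 95000 nM, which sits within the scatter of both compound 3 and compound 1, so no order among the three measured compounds can be claimed.

Compound 4 `O=c1c(C2N=C(c3ccccc3)SS2)coc2cc(Cl)ccc12` is the counterpart of compound 2 on the second core, differing from it by hydrogen in place of chloro on an aromatic carbon. The two "place" descriptions for the pair compound 3 to compound 1 and the pair compound 2 to compound 4 are identical word for word, so this is the same change made on the other core. For the measured compounds named here, only the single earlier instance of it is known, and that instance stayed within the scatter.

The expectation for compound 4 is a step of a 1.1-fold lower number from compound 2 to compound 4 (0.05 log units; within the scatter), matching the earlier step in size, because the change from compound 3 to compound 1 gave a 1.1-fold lower number from compound 3 to compound 1 (0.05 log units; within the scatter). Going by the values given here, compound 4 is accordingly estimated at 85000 nM, with a range from 42000 nM to 170000 nM reflecting that only one precedent supports the transfer between cores.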

Compound 4, half-maximal inhibitory concentration: 57500 nM
Beside the measured number, compound 4's estimate is 1.5-fold (0.17 log units) above it; the measured number falls inside the stated range.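

On the second core, hydrogen in place of chloro on an aromatic carbon gives a 1.7-fold lower number from compound 2 to compound 4 (0.22 log units; within the scatter) in this assay. Set beside the same change on the first core, this step does not stand apart: the same change on two cores in this assay, a 1.1-fold lower number (0.05 log units; within the scatter) from compound 3 to compound 1 and a 1.7-fold lower number (0.22 log units; within the scatter) from compound 2 to compound 4, 1.5-fold (0.17 log units) apart, within the scatter of two such steps. On both cores the change therefore stays within the scatter, and the two cores give no sign of answering it differently, but two pairs are too few to support a rule for the series, and steps this small do not show that the change would stay within the scatter on any other core.

Going by these compounds, only chloro and hydrogen are compared at this aromatic carbon, so it remains open whether another group there, such as methoxy, an amine or a carboxylic acid, would give a step beyond the scatter in this assay. Both pairs also vary only this one place, which leaves open what a change elsewhere on either core, for example a nitrile or a longer chain, would do to the number in this assay.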